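Removing One Hydroxy Group: What Compound 4 Might Show

The source may hold more compounds than are shown below. What is called first, only, known or untested is meant among the compounds shown, and "the series" means these compounds.

Of the compounds shown here, three built on one shared core have been tested in a functional assay on 786-0 cells (Homo sapiens) for inhibition, read by sulforhodamine B assay, with a stated time of 48 h; on this read-out higher numbers stand for weaker inhibition of growth and lower numbers for stronger inhibition of growth. Compound 1 `CCOC(=O)C1=C(C)NC(=S)NC1c1ccc(O)c(O)c1` gives 28.3 ug/mL in this assay. Compound 2 `CCOC(=O)C1=C(C)NC(=S)NC1c1cc(OC)c(O)c(OC)c1` gives 13.4 ug/mL. Compound 3 `CCOC(=O)C1=C(C)NC(=O)NC1c1ccc(O)c(O)c1` gives 25.7 ug/mL. On these three numbers compound 3 stands second highest; its nearest neighbour is compound 1, whose number lies within the scatter of its own, and its furthest is compound 2, whose number also lies within the scatter, so the three values cannot be set apart with confidence.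

Compound 4 `CCOC(=O)C1=C(C)NC(=O)NC1c1ccc(O)cc1` has not yet been measured. It differs from compound 3 in a single place: hydrogen in place of hydroxy on an aromatic carbon. Among the measured compounds shown here, no measured pair shows this change on its own, so there is no step to read it from. For the measured compounds named here, the only guide is that compounds 1, 2 and 3, which differ among themselves in several places, all fall inside one band of scatter. The step in this assay is therefore expected to be small: either none beyond the scatter, or a modest move toward a higher number, that is weaker inhibition of growth. Compound 4 is expected to give about 32 ug/mL, within a range from 15 ug/mL to 65 ug/mL. This estimate means an expected step of a 1.2-fold higher number from compound 3 to compound 4 (0.10 log units; within the scatter).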

Compound 4, concentration for 50% growth inhibition: 25.8 ug/mL
Estimate against measurement, compound 4: 1.2-fold (0.09 log units) above; the range from low to high includes it.
By their numbers in this assay, from the lowest: compounds 2, 3, 4 and 1 (each within the scatter of the next, the first and the last beyond it).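

Among the compounds shown here, compound 3 and compound 4 form the first pair here that differs in one place only, so they give the first direct reading of a single change in this assay. Hydrogen in place of hydroxy on an aromatic carbon, at a place ortho to a hydroxy group and meta to a large group, gives a 1.0-fold higher number from compound 3 to compound 4 (0.00 log units; within the scatter), which means that in this one pair the loss of that hydroxy leaves the two numbers impossible to tell apart. None of the measurements shown offers a reason for this result.

This is a single pair in a single assay, and it leaves open whether the same exchange would read the same way on compound 1, which carries the same two hydroxy groups but differs from compound 3 elsewhere on the shared core. The compounds shown also leave open what an amine, a carboxylic acid or a chlorine atom would give at this place, and what would follow if the remaining hydroxy group were also replaced by hydrogen.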